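Methyl for Fluoro on the Amide Aryl Ring

The compounds below may be only part of what the source reports. "The series", "measured", "known", "first", "only" and "open" are said of these compounds alone.

Compound 1, `O=C(Nc1cccc(-c2oc3cc(-c4ccc(F)cc4)ccc3c(=O)c2O)c1)c1ccccc1F`: 17400 nM
Compound 2, `Cc1ccc(C(=O)Nc2cccc(-c3oc4cc(-c5ccc(F)cc5)ccc4c(=O)c3O)c2)cc1`: 12900 nM
Compound 3, `O=C(Nc1cccc(-c2oc3cc(-c4ccc(F)cc4)ccc3c(=O)c2O)c1)c1ccc(F)cc1F`: 9640 nM

These three compounds share one core and differ only in the aryl group attached to the amide carbonyl. All were tested in a functional assay on GTL 16 cells for antiproliferative activity against GTL 16 cell line (Homo sapiens), read by CCK-8 assay, with a stated time of 72 h; a higher number here means a weaker inhibitor, a lower number a stronger inhibitor. Compound 1 shows the highest number of the three, yet both steps away from it, a 1.3-fold lower number from compound 1 to compound 2 (0.13 log units; within the scatter) and a 1.8-fold lower number from compound 1 to compound 3 (0.26 log units; within the scatter), lie within the scatter, so the three cannot be ranked on these data.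

Compound 4, `Cc1ccccc1C(=O)Nc1cccc(-c2oc3cc(-c4ccc(F)cc4)ccc3c(=O)c2O)c1`, has not yet been measured. It differs from compound 1 in one place: methyl in place of fluoro on an aromatic carbon. Within the data shown here, two measured steps touch the same ring. In a 1.3-fold lower number from compound 1 to compound 2 (0.13 log units; within the scatter) the 2-fluorophenyl group is exchanged for a 4-methylphenyl group, and in a 1.8-fold lower number from compound 1 to compound 3 (0.26 log units; within the scatter) a second fluoro is added to it; neither moves the number beyond the scatter. With such small responses to changes on this ring, no step beyond the scatter is expected for this assay either. The estimated step of a 1.2-fold lower number from compound 1 to compound 4 (0.06 log units; within the scatter) is accordingly expected to be small. Compound 4 is expected to give about 15000 nM, most likely between 7000 nM and 32000 nM.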

Compound 4, half-maximal inhibitory concentration: 24800 nM
The estimate for compound 4 lay 1.7-fold (0.22 log units) below the measured number; measured number inside the range.
By their numbers in this assay, from the lowest: compounds 3, 2, 1 and 4 (each within the scatter of the next, the first and the last beyond it).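

On this aromatic carbon, ortho to a large group, this assay does not separate fluoro from methyl (a 1.4-fold higher number from compound 1 to compound 4 (0.15 log units; within the scatter)), so 2-fluorophenyl and 2-methylphenyl cannot be told apart on the amide carbonyl. Among these compounds, the new compound does show that the aryl group on this carbonyl can matter, since exchanging 2,4-difluorophenyl for 2-methylphenyl gives the first step in this set beyond the scatter, though only a modest one (a 2.6-fold higher number from compound 3 to compound 4 (0.41 log units; beyond the scatter)), whereas moving between 4-methylphenyl and 2-methylphenyl stays within it (a 1.9-fold higher number from compound 2 to compound 4 (0.28 log units; within the scatter)), leaving those two groups unranked. Among the compounds shown here, nothing available here explains the one step that stands beyond the scatter.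

The compounds shown leave open how this same aromatic carbon responds to a group different from the small fluoro and methyl, such as a methoxy, an amine or a carboxylic acid. They also leave open whether changes on this aryl ring can ever give more than a modest step, or whether a larger shift would need a change elsewhere on the shared core.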